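This account rests on a few compounds, and the source may have more. Where it says the series, first, only, none or still open, it means among the compounds named here.

Going by the values given here, in a functional assay on CHO cells for agonist activity at adenosine receptor A1 (Homo sapiens), read by fluorescence and ERK phosphorylation, with stated times of 30 min and 1.5 h, tested at 3 uM (on this read-out lower numbers stand for a weaker effect and higher numbers for a stronger effect at the one concentration tested), compound 2 `Nc1scc(-c2ccc(Br)cc2)c1C(=O)c1ccc(Cl)cc1` gives 45%, the lower of the two numbers measured so far. Among the compounds with values here, compound 1 `Nc1scc(-c2ccccc2F)c1C(=O)c1ccc(Cl)cc1` gives 70% in this assay, and the only measured step, a number 25 percentage points lower from compound 1 to compound 2 (beyond the scatter), came with 4-bromophenyl in place of 2-fluorophenyl. Compound 3 `Nc1scc(-c2ccc(I)cc2)c1C(=O)c1ccc(Cl)cc1` differs from compound 2 by iodo in place of bromo on an aromatic carbon. Within the data shown here, no measured step changes one halogen for another at the same place, so that earlier step gives little guidance here. The step of no change at the digits printed from compound 2 to compound 3 (within the scatter) is therefore expected to stay within the scatter. Compound 3 is estimated at 45%, between 25% and 65%.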

Compound 3, a percentage reported as activity, at one concentration (the size of the read-out at that concentration, not a potency): 54%
For compound 3 the middle estimate is 9 percentage points below the measured one; low and high end bracket the measured number.
By their numbers in this assay, from the lowest: compounds 2 and 3 (each within the scatter of the next); then compound 1.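

In this assay, exchanging one halogen for a larger one at this place on the ring leaves the read-out within the usual scatter: a number 9 percentage points higher from compound 2 to compound 3 (within the scatter). The 4-iodophenyl compound also stays clearly under the 2-fluorophenyl compound, with a number 16 percentage points lower from compound 1 to compound 3 (beyond the scatter), so the earlier drop is not confined to bromo. No available evidence bears on the reason for this.

Compound 1 and compound 3 differ in both the halogen and its place on the ring, so these two changes remain unseparated. On these data alone, whether an amine or a carboxylic acid at this place would keep the effect remains open.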